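Removing one fluoro from compound 1

The compounds below may be only part of what the source reports. "The series", "measured", "known", "first", "only" and "open" are said of these compounds alone.

compound 1 `O=C(N/N=C/c1ccc(F)cc1)Nc1ccc(Oc2ccnc3[nH]ccc23)c(F)c1` gives 2330 nM
compound 2 `O=C(N/N=C/c1ccc(O)cc1O)Nc1ccc(Oc2ccnc3[nH]ccc23)c(F)c1` gives 13000 nM

For the measured compounds named here, in a functional assay on PC-3 cells (Homo sapiens) for antiproliferative activity, read by MTT assay, with a stated time of 72 h (on this read-out lower numbers stand for stronger inhibition and higher numbers for weaker inhibition), compound 1 has the lower of the two numbers so far. Compound 3 `O=C(N/N=C/c1ccc(F)cc1)Nc1ccc(Oc2ccnc3[nH]ccc23)cc1` differs from it by one change hydrogen in place of fluoro on an aromatic carbon in which hydrogen stands in place of fluoro on an aromatic carbon. Going by the values given here, the only measured step of a 5.6-fold higher number from compound 1 to compound 2 (0.75 log units; beyond the scatter) is modest and concerns a different place in the molecule, so it bears only loosely on this change. No step beyond the scatter is therefore expected in this assay and the estimated step is small a 1.2-fold higher number from compound 1 to compound 3 (0.08 log units; within the scatter) toward a slightly higher number. Compound 3 is expected at 2800 nM within an estimated range of 1000 nM to 7500 nM for now.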

Compound 3, half-maximal inhibitory concentration: 7490 nM
Estimate against measurement, compound 3: 2.7-fold (0.43 log units) below, within the range that was stated.
By their numbers in this assay, from the lowest: compound 1; then compounds 3 and 2 (each within the scatter of the next).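

In this assay, replacing the fluoro with hydrogen gives a 3.2-fold higher number from compound 1 to compound 3 (0.51 log units; beyond the scatter), so this single atom on the aromatic carbon makes a measurable difference, which the earlier step, at a different place in the molecule, could not show. The step is modest but beyond the scatter, and compound 1, which carries the fluoro, keeps the lower number. No measurement shown here explains why the fluoro matters at this position. From the compounds shown here alone, whether a chloro, methyl or methoxy group on this same carbon would match the fluoro or do better remains open.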